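The source may hold more compounds than are shown below. What is called first, only, known or untested is meant among the compounds shown, and "the series" means these compounds.

Working notes on the series. Compound 1 `CC(C)n1ncc2c(C(=O)NCc3cn(-c4ccc(F)cc4)nn3)cccc21` is tested in a functional assay on MCF7 cells (Homo sapiens) for inhibition, read by MTT assay, with a stated time of 72 h (a lower number here means a stronger inhibitor, a higher number a weaker inhibitor), and compound 1 gives only a limit of > 40000 nM. Compound 2 `CC(C)n1ncc2c(C(=O)NCc3cn(-c4cccc(Br)c4)nn3)cccc21` in this assay likewise returns only a limit, > 40000 nM. Compound 3 `Cc1ccccc1-n1cc(CNC(=O)c2cccc3c2cnn3C(C)C)nn1` in this assay also returns only a limit, > 40000 nM. The steps between these three compounds are accordingly unreadable: a step that the two limits leave unreadable from compound 1 to compound 2, a step that the two limits leave unreadable from compound 1 to compound 3 and a step that the two limits leave unreadable from compound 2 to compound 3, since all values sit at one limit (the limit of > 40000 nM in this assay, at which 3 of the 3 values shown sit). Compound 3 thus stands at that limit, and no number separates it from compound 1 or compound 2 in this assay.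

Compound 4 `CC(C)n1ncc2c(C(=O)NCc3cn(Cc4ccc(C#N)cc4)nn3)cccc21` has not yet been measured. It differs from compound 3 as follows: 4-cyanobenzyl in place of 2-methylphenyl on an aromatic nitrogen. Among the measured compounds shown here, none of the measured steps has a readable size, so no direction can be drawn from them for this change. The expected step in this assay is a number no higher from compound 3 to compound 4 (the limit leaves the size open), that is, no movement beyond the scatter is expected. Compound 4 is estimated in this assay at 40000 nM, within a range of 10000 nM to 160000 nM, most likely again reported as a limit.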

Compound 4, half-maximal inhibitory concentration: > 40000 nM
Compound 4 gave a limit, no number (the forecaster's own chance of this, stated with the estimate: 75%); the middle value lies on the limit itself.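

Compound 4 gives > 40000 nM in this assay as a limit, not a number. Among the compounds shown here, no step from compound 1, compound 2 or compound 3 to compound 4 can be read: the limit of > 40000 nM in this assay, at which 4 of the 4 values shown sit. The compounds shown leave open how any of these groups on the aromatic nitrogen would rank in this assay.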